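Chloro to fluoro on the outer ring of compound 3

This account rests on a few compounds, and the source may have more. Where it says the series, first, only, none or still open, it means among the compounds named here.

Measured so far in a functional assay on the whole organism (strain NMRI) with Mus musculus as the target, with a stated time of 60 min, at a dose of 10 mg/kg by the intraperitoneal route; a higher number here means a stronger effect of the compound at the dose given, a lower number a weaker effect:
compound 1 `CSc1nnc(Cc2ccc(Cl)cc2Oc2ccccc2F)[nH]1` gives 121%
compound 2 `CCSc1nnc(Cc2ccc(Cl)cc2Oc2ccccc2F)[nH]1` gives 144%
compound 3 `Nc1nnc(Cc2ccc(Cl)cc2Oc2ccccc2Cl)o1` gives 132%

On these numbers compound 3 stands second highest of three: compound 1 sits lower by a margin beyond the scatter, compound 2 higher by a similar margin. Within the data shown here, the only step measured is a number 23 percentage points higher from compound 1 to compound 2 (beyond the scatter), which concerns a different part of the molecule and does not bear on the change at hand. Compound 4 `Nc1nnc(Cc2ccc(Cl)cc2Oc2ccccc2F)o1` differs from compound 3 by fluoro in place of chloro on an aromatic carbon. Among the measured compounds shown here, no measured pair shows this exchange, so the step is expected to be small: a number 2 percentage points lower from compound 3 to compound 4 (within the scatter) is estimated to stay within the scatter in this assay. Compound 4 is expected to give about 130%, with a range from 105% to 155%.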

Compound 4, a percentage reported as activity, at one dose (the size of the read-out at that dose, not a potency): 129%
The estimate for compound 4 lay 1 percentage points above the measured number, within the range that was stated.
By their numbers in this assay, from the lowest: compounds 1, 4 and 3 (each within the scatter of the next, the first and the last beyond it); then compound 2.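

In this assay, the change from 2-chlorophenyl to 2-fluorophenyl stays within the scatter (a number 3 percentage points lower from compound 3 to compound 4 (within the scatter)), so this position accepts either halogen at the dose given. With 2-fluorophenyl held constant, the five-membered aromatic ring groups can now be compared: a number 15 percentage points lower from compound 2 to compound 4 (beyond the scatter), whereas a number 8 percentage points higher from compound 1 to compound 4 (within the scatter). No measurement available here accounts for these steps. As far as these compounds go, whether bromo or methoxy at this position would keep the read-out remains open. A single dose also shows only a stronger or weaker effect at that dose across the series.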